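The source may report more compounds than this note shows. Statements on the series, on what has been measured and on what is new or still open speak of the compounds shown alone.

Among the measured compounds shown here, compound 2 `Cc1ccccc1S(=O)(=O)N1CCC[C@H]1C(=O)Nc1ccc(C(=O)O)cc1` stands lowest of the two compounds measured so far in a functional assay on the whole organism for inhibition, with Rattus norvegicus as the target, read by paw edema, with a stated time of 1 h, at a dose of 100 mg/kg by the oral route; a lower number here means less inhibition, a higher number more inhibition at the dose given (going by the name of the read-out): compound 2 gives 39.4%, while compound 1 `Cc1ccc(S(=O)(=O)N2CC(O)C[C@H]2C(=O)Nc2ccc(C(=O)O)cc2)cc1` gives 60%, a gap beyond the usual scatter. Compound 3 `Cc1ccc(S(=O)(=O)N2CCC[C@H]2C(=O)Nc2ccc(C(=O)O)cc2)cc1` has not yet been measured. It differs from compound 2 by 4-methylphenyl in place of 2-methylphenyl on a sulfonyl sulfur. Because compound 1, which also carries a 4-methylphenyl on the sulfonyl sulfur, gives 60%, a modest rise beyond the scatter is expected, though compound 1 differs in more than this one place. The expected step is a number 10.6 percentage points higher from compound 2 to compound 3 (beyond the scatter), so compound 3 is estimated at 50%, with a likely range from 32% to 68%.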

Compound 3, a percentage reported as inhibition, in the whole organism at one dose (the size of the read-out at that dose, not a potency): 31.5%
Beside the measured number, compound 3's estimate is 18.5 percentage points above it; measured number outside the range, below it.
By their numbers in this assay, from the lowest: compounds 3 and 2 (each within the scatter of the next); then compound 1.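

In this assay, 4-methylphenyl in place of 2-methylphenyl on a sulfonyl sulfur gives a number 7.9 percentage points lower from compound 2 to compound 3 (within the scatter), so this change does not separate the two compounds. Hydrogen in place of hydroxy on a saturated ring carbon gives a number 28.5 percentage points lower from compound 1 to compound 3 (beyond the scatter), so the higher number of compound 1 goes with that hydroxy and not with the 4-methylphenyl it shares with compound 3. Nothing available explains either step. As far as these compounds go, it remains open whether the hydroxy would have the same effect alongside 2-methylphenyl, and what an amine or a methoxy group at that ring carbon would give.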